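Benzyloxy to methoxy on the chromone series: a single step

The source may hold more compounds than are shown below. What is called first, only, known or untested is meant among the compounds shown, and "the series" means these compounds.

Measured so far:
compound 1 `COc1cc2oc(-c3ccccc3)cc(=O)c2c(O)c1OCCCCN1CCCCC1` — 21900 nM
compound 2 `CN1CCN(CCCOc2c(OCc3ccccc3)cc3oc(-c4ccccc4)cc(=O)c3c2O)CC1` — 4100 nM

In a functional assay on BCG823 cells (Homo sapiens) for antiproliferative activity, read by MTT assay, with a stated time of 48 h (on this read-out lower numbers stand for stronger inhibition and higher numbers for weaker inhibition), compound 2 gives 4100 nM, the lowest of the two numbers, with compound 1 at 21900 nM standing beyond the scatter. Compound 3 `COc1cc2oc(-c3ccccc3)cc(=O)c2c(O)c1OCCCN1CCN(C)CC1` differs from compound 2 by hydrogen in place of phenyl on a saturated chain carbon bound to an oxygen on an aromatic ring. Among the measured compounds shown here, no step between measured compounds isolates this change; compound 1, which also carries methoxy, is the weaker of the two, but it differs from compound 2 in more than one place. A weakening beyond the scatter is expected for compound 3, a step of a 2.4-fold higher number from compound 2 to compound 3 (0.39 log units; beyond the scatter), giving an estimated 10000 nM with a range from 4000 nM to 30000 nM.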

Compound 3, half-maximal inhibitory concentration: 31300 nM
For compound 3 the middle estimate is 3.1-fold (0.50 log units) below the measured one; measured number above the stated range.
By their numbers in this assay, from the lowest: compound 2; then compounds 1 and 3 (each within the scatter of the next).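

In this assay, the change from benzyloxy to methoxy now stands alone as a single step, a 7.6-fold higher number from compound 2 to compound 3 (0.88 log units; beyond the scatter), so phenyl on a saturated chain carbon bound to an oxygen on an aromatic ring matters in this pair. With methoxy held constant, 4-methylpiperazin-1-yl in place of (piperidin-1-yl)methyl gives a 1.4-fold higher number from compound 1 to compound 3 (0.16 log units; within the scatter), which does not separate those two compounds. No measured evidence bears on the reason for either result.

Open, on these data alone, is whether ethoxy, phenethyloxy or a 4-chlorobenzyloxy group would give numbers nearer compound 2 or compound 3. Also open, as far as these compounds go, is whether the benzyloxy step holds with the piperidine side chain of compound 1.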